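The source may report more compounds than this note shows. Statements on the series, on what has been measured and on what is new or still open speak of the compounds shown alone.

Of the compounds shown here, three with a shared core have been measured in an assay on isolated protein for displacement of a labelled ligand from metabotropic glutamate receptor 5 (Homo sapiens), with a stated time of 60 min, tested at 1 uM; on this read-out higher numbers stand for more inhibition at the one concentration tested (going by the name of the read-out) and lower numbers for less inhibition. Compound 1, `COc1ccc2ncc(S(=O)(=O)c3ccc(Cl)c(Cl)c3)c(N3CCC(C)CC3)c2c1`, gives 87% in this assay. Compound 3, `COc1ccc(S(=O)(=O)c2cnc3ccc(F)cc3c2N2CCC(C)CC2)cc1Cl`, gives 82%. Compound 2, `CC1CCN(c2c(S(=O)(=O)c3ccc(F)cc3)cnc3c(F)cccc23)CC1`, gives 26% and stands lowest of the three numbers, the nearest being compound 3 and the furthest compound 1, both beyond the usual scatter. Within the data shown here, compound 1 and compound 3 differ from compound 2 in more than one place, so no single step between measured compounds can be read from them.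

The next compound, compound 4, `CC1CCN(c2c(S(=O)(=O)c3ccccc3)cnc3c(F)cccc23)CC1`, differs from compound 2 in one place only: hydrogen in place of fluoro on an aromatic carbon. Among the measured compounds shown here, no measured pair shows what this change does in this assay. Given that the nearest measured compounds differ in several places, the step is expected to be small, in either direction or none beyond the scatter, so compound 4 is estimated at 25%, with a range from 5% to 50%, meaning an expected step of a number 1 percentage points lower from compound 2 to compound 4 (within the scatter).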

Compound 4, a percentage reported as inhibition, at one concentration (the size of the read-out at that concentration, not a potency): 13%
Compound 4: middle estimate off by 12 percentage points, on the high side; low and high end bracket the measured number.
By their numbers in this assay, from the lowest: compound 4; then compound 2; then compounds 3 and 1 (each within the scatter of the next).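

In this assay, replacing fluoro with hydrogen on the aromatic carbon para to a large group, the change from 4-fluorophenyl to phenyl, gives a number 13 percentage points lower from compound 2 to compound 4 (beyond the scatter). Among these compounds, this is the first step here that can be read in one place, and it shows that the read-out responds, modestly, to this single change at this position. Why it does so cannot be said, as nothing measured on these compounds bears on a cause.

The compounds shown leave open how a trifluoromethyl, a nitrile or an amine at this same position would compare with fluoro and hydrogen. They also leave open whether the same change would give a step of similar size on compounds carrying the other substituents of compound 1 or compound 3.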